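Substituents on the ring nitrogen of the shared core

This account rests on a few compounds, and the source may have more. Where it says the series, first, only, none or still open, it means among the compounds named here.

Compound 2 `C[C@@H](O[C@@H]1CN(C(=O)[C@@H]2COC(=O)N2)C[C@H]1c1ccc(F)cc1)c1cc(C(F)(F)F)cc(C(F)(F)F)c1` gives 0.34 nM in an assay on CHO cells for displacement of a labelled ligand from Substance-P receptor (Homo sapiens) (on this read-out higher numbers stand for weaker inhibition and lower numbers for stronger inhibition), the highest of the three numbers recorded so far. Compound 1 `C[C@@H](O[C@@H]1CN(C(=O)C(C)(C)C)C[C@H]1c1ccccc1)c1cc(C(F)(F)F)cc(C(F)(F)F)c1` gives 0.18 nM in this assay, which sits within the scatter of the value for compound 2. Compound 3 `C[C@@H](O[C@@H]1CN(C(=O)N2CCOCC2)C[C@H]1c1ccccc1)c1cc(C(F)(F)F)cc(C(F)(F)F)c1` gives 0.16 nM in this assay, and the gap from compound 2 to compound 3 is just beyond the scatter. For the measured compounds named here, the one measured step at the ring nitrogen, a 1.1-fold lower number from compound 1 to compound 3 (0.05 log units; within the scatter), shows that an exchange of the group on the carbonyl carbon there passes without a change beyond the scatter. Compound 4 `CC1=C(N2C[C@@H](O[C@H](C)c3cc(C(F)(F)F)cc(C(F)(F)F)c3)[C@H](c3ccc(F)cc3)C2)CCC1=O` carries 2-methyl-3-oxocyclopent-1-en-1-yl in place of (2-oxo-1,3-oxazolidin-4-yl)carbonyl on an amine nitrogen in a ring. Going by the values given here, this removes the carbonyl on the ring nitrogen entirely rather than exchanging the group on it, so no measured step bears on it directly; the tolerance seen from compound 1 to compound 3 only hints that this position accepts variation. Compound 4 is therefore expected to land near compound 2, with a step of a 1.8-fold higher number from compound 2 to compound 4 (0.25 log units; within the scatter) judged likely but uncertain, and its estimate in this assay is 0.6 nM with a range from 0.2 nM to 2.5 nM.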

Compound 4, half-maximal inhibitory concentration: 0.13 nM
Compound 4: the middle estimate sits 4.6-fold (0.66 log units) above what was measured; measured number outside the range, below it.
By their numbers in this assay, from the lowest: compounds 4, 3, 1 and 2 (each within the scatter of the next, the first and the last beyond it).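

In this assay, for the compounds shown here, the exchange of (2-oxo-1,3-oxazolidin-4-yl)carbonyl for 2-methyl-3-oxocyclopent-1-en-1-yl gives a 2.6-fold lower number from compound 2 to compound 4 (0.42 log units; beyond the scatter) and is the first step at this position beyond the scatter, while a 1.1-fold lower number from compound 1 to compound 3 (0.05 log units; within the scatter) stays within it. The amine nitrogen in the ring therefore needs no carbonyl attached directly to it for a low number, and the step is modest but runs towards stronger inhibition. The entering group, with a ring of carbon only, 0 hydrogen-bond donors and 1 hydrogen-bond acceptor, is accepted here, and nothing measured on these compounds accounts for the step.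

Open, as far as these compounds go, is whether the methyl and the oxo group of 2-methyl-3-oxocyclopent-1-en-1-yl each contribute, and whether a plain benzyl group or a carboxylic acid on that nitrogen would hold up in this assay as well. No pair shown differs only in 4-fluorophenyl against phenyl, so the part played by that fluorine cannot be read.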